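This account rests on a few compounds, and the source may have more. Where it says the series, first, only, none or still open, it means among the compounds named here.

Two measured compounds set the frame. In an ADME assay on MT2 cells (Homo sapiens) for cytotoxicity, read by MTT assay (on this read-out higher numbers stand for lower toxicity in this test and lower numbers for higher toxicity in this test), compound 1 `Fc1cccc(F)c1Cc1cnc(Nc2ccc(CCOc3ccncc3)cc2)o1` gives 11000 nM. Compound 2 `Clc1cccc(Cl)c1Cc1nnc(Nc2ccc(COCc3ccoc3)cc2)o1` gives 21000 nM in this assay, and the two numbers lie within the usual scatter of each other, so neither stands apart. Compound 3 `OCc1ccc(Nc2ncc(Cc3c(F)cccc3F)o2)cc1` has not yet been measured in this assay. It differs from compound 1 in one place: hydroxy in place of ((pyridin-4-yl)oxy)methyl on a saturated chain carbon bound to an aromatic carbon. Among the measured compounds shown here, no comparable step between measured compounds is known here. The change is expected to bring a step of a 1.4-fold higher number from compound 1 to compound 3 (0.13 log units; within the scatter), none beyond the scatter. Compound 3 is therefore estimated at 15000 nM, between 6000 nM and 40000 nM.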

Compound 3, half-maximal cytotoxic concentration: > 100000 nM
Compound 3: only a limit was reported (the forecaster's own chance of this, stated with the estimate: 20%); middle value at least 6.6-fold (0.82 log units) from the limit.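

This position on the saturated chain carbon bound to an aromatic carbon clearly matters: in this assay, hydroxy in place of ((pyridin-4-yl)oxy)methyl gives an at least 9.0-fold higher number from compound 1 to compound 3 (0.95 log units; beyond the scatter), a shift towards lower toxicity in this test. From the compounds shown here alone, for compound 3, > 100000 nM is a limit of the assay and not a number: the limit of > 100000 nM in this assay, at which 1 of the 3 values shown sits. The full size of the step therefore stays unknown. The compounds shown leave open whether the ring or the hydroxy group drives this change. An amine or a methoxy group at this place could help to separate the two.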